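A Second Methoxy Group Beside the Phenol

The source may report more compounds than this note shows. Statements on the series, on what has been measured and on what is new or still open speak of the compounds shown alone.

Of the compounds shown here, two sharing one core have been measured so far. Compound 1 `CCOC(=O)C1=C(C)NC(=S)NC1c1ccc(O)cc1` gives 47.6 ug/mL in a functional assay on PC-3 cells (Homo sapiens) for inhibition, read by sulforhodamine B assay, with a stated time of 48 h; on this read-out lower numbers stand for stronger inhibition of growth and higher numbers for weaker inhibition of growth. For the measured compounds named here, compound 2 `CCOC(=O)C1=C(C)NC(=S)NC1c1ccc(O)c(OC)c1` gives 72.6 ug/mL in this assay, the higher of the two numbers, and its only neighbour is compound 1. The step between them is a 1.5-fold higher number from compound 1 to compound 2 (0.18 log units; within the scatter), which counts as no real change. Compound 3 `CCOC(=O)C1=C(C)NC(=S)NC1c1cc(OC)c(O)c(OC)c1` has not been measured yet. It differs from compound 2 in one place: methoxy in place of hydrogen on an aromatic carbon. Going by the values given here, the only measured step that bears on this change is a 1.5-fold higher number from compound 1 to compound 2 (0.18 log units; within the scatter), in which a group of the same kind entered the same ring and moved the number by an amount that lies within the ordinary spread. On that basis the step of a 1.2-fold higher number from compound 2 to compound 3 (0.09 log units; within the scatter) is expected to be small, perhaps a slightly higher number, but nothing beyond the scatter. The estimate for compound 3 is 90 ug/mL, with a range from 45 ug/mL to 180 ug/mL.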

Compound 3, concentration for 50% growth inhibition: 19 ug/mL
The estimate for compound 3 lay 4.7-fold (0.68 log units) above the measured number; the whole stated range lies above it.
By their numbers in this assay, from the lowest: compound 3; then compounds 1 and 2 (each within the scatter of the next).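

For the compounds shown here, a methoxy group on the aromatic carbon ortho to a hydroxy group and meta to a methoxy group gives a 3.8-fold lower number from compound 2 to compound 3 (0.58 log units; beyond the scatter) in this assay, so stronger inhibition of growth is seen here for the first time in this small set. The same kind of replacement gave only a 1.5-fold higher number from compound 1 to compound 2 (0.18 log units; within the scatter), so adding a methoxy group to this ring does not have one fixed outcome, and its effect can depend on what the ring already carries. No measurement shown here accounts for the lower number in compound 3.

From the compounds shown here alone, whether this position needs a methoxy group in particular remains open, since an ethoxy group, a chlorine atom or an amine could give a different number there. Going by these compounds, it is also open whether the lower number in compound 3 depends on the hydroxy group.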